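The source may report more compounds than this note shows. Statements on the series, on what has been measured and on what is new or still open speak of the compounds shown alone.

Measured so far:
compound 1 `C=CCn1c(=O)n([C@H]2CO[C@@H](CO)C2)c2nc(N)nc(O)c21` — 0%
compound 2 `C=CCn1c(=O)n(CCCC)c2nc(N)nc(O)c21` — 21%

Going by the values given here, compound 2 stands highest of the two numbers in a functional assay on YAC-1 cells (Mus musculus); a higher number here means a larger maximal response, a lower number a smaller maximal response; the only other point is compound 1, and the gap is a number 21 percentage points higher from compound 1 to compound 2 (beyond the scatter). Compound 3 `C=CCn1c(=O)n(C2C=CC(CO)O2)c2nc(N)nc(O)c21` differs from compound 2 by a group of 7 heavy atoms (5 carbon, 2 oxygen; one five-membered non-aromatic ring with 1 hetero atom) in place of a group of 4 heavy atoms (4 carbon; no ring), on an aromatic nitrogen. Among the compounds with values here, the one measured step that bears on this change is the reverse kind of exchange, a cyclic oxygen-bearing group giving way to butyl, which was a number 21 percentage points higher from compound 1 to compound 2 (beyond the scatter). A downward step of comparable size, a number 16 percentage points lower from compound 2 to compound 3 (beyond the scatter), is therefore expected. Compound 3 is estimated to give 5% in this assay, with a range from 0% to 20%.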

Compound 3, largest response reached (reported as maximal response), in percent of the reference or control that the assay uses: 89%
The estimate for compound 3 lay 84 percentage points below the measured number; measured number outside the range, above it.
By their numbers in this assay, from the lowest: compound 1; then compound 2; then compound 3.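

At the aromatic nitrogen, a five-membered non-aromatic ring with 1 hetero atom does not by itself lower the response in this assay: the butyl exchange now gives a number 68 percentage points higher from compound 2 to compound 3 (beyond the scatter), opposite in direction to the earlier step of a number 21 percentage points higher from compound 1 to compound 2 (beyond the scatter). Two ring-bearing groups with the same heavy-atom count also separate widely, with a number 89 percentage points higher from compound 1 to compound 3 (beyond the scatter), so neither the presence of a ring nor the heavy-atom count sets the response across these compounds.

Still open, from the compounds shown here alone, is whether a hydroxybutyl or hexyl chain at this nitrogen would approach compound 3 or stay nearer compound 2. No available evidence accounts for the gap between the two ring-bearing groups.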